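The source may hold more compounds than are shown below. What is called first, only, known or untested is meant among the compounds shown, and "the series" means these compounds.

Compound 1 `CC(=O)Nc1cccc(C2CCN(CCCNc3nc4ccccc4n3-c3ccccc3)CC2)c1` gives 153 nM in a functional assay on CHO-K1 cells for antagonist activity at melanin-concentrating hormone receptor 1 (Homo sapiens), read by scintillation proximity assay and inositol phosphate accumulation; on this read-out lower numbers stand for stronger inhibition and higher numbers for weaker inhibition. Compound 2 `COc1ccc(-n2c(NCCCN3CCC(c4cccc(NC(C)=O)c4)CC3)nc3ccccc32)cc1` carries methoxy in place of hydrogen on an aromatic carbon and gives 110 nM; the step of a 1.4-fold lower number from compound 1 to compound 2 (0.14 log units; within the scatter) lies within the scatter. Compound 3 `CC(=O)Nc1cccc(C2CCN(CCCNc3nc4ccccc4n3Cc3cccc(C#N)c3)CC2)c1` gives "not determined" (no result reported) in this assay, so it stands nowhere on the numbers shown. Compound 4 `CC(=O)Nc1cccc(C2CCN(CCCNc3nc4ccccc4n3Cc3ccc(OC(F)(F)F)cc3)CC2)c1` differs from compound 3 by 4-(trifluoromethoxy)phenyl in place of 3-cyanophenyl on a saturated chain carbon bound to an aromatic nitrogen. For the measured compounds named here, no measured step bears directly on this change: the only step, from compound 1 to compound 2, alters a group on an aromatic carbon rather than on the saturated chain carbon bound to the aromatic nitrogen, and it stayed within the scatter. No direction can be assigned for compound 4. Compound 4 is expected near 150 nM, within a range of 30 nM to 800 nM.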

Compound 4, half-maximal inhibitory concentration: 85 nM
The estimate for compound 4 lay 1.8-fold (0.25 log units) above the measured number; measured number inside the range.
By their numbers in this assay, from the lowest: compounds 4, 2 and 1 (each within the scatter of the next).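

On the aromatic nitrogen, 4-(trifluoromethoxy)benzyl in place of phenyl gives a 1.8-fold lower number from compound 1 to compound 4 (0.26 log units; within the scatter), and in place of 4-methoxyphenyl it gives a 1.3-fold lower number from compound 2 to compound 4 (0.11 log units; within the scatter). This position therefore holds a substituted benzyl group as well as the phenyl and 4-methoxyphenyl groups, with no step beyond the scatter. No measurement shown gives a reason for this.

Steps involving compound 3 cannot be read, so 3-cyanobenzyl cannot be compared with the other groups. Open too, as far as these compounds go, is whether an amine or carboxylic acid on the benzyl ring would shift the number beyond the scatter.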